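Aryl variation at the saturated ring carbon

A few compounds are considered here, and "the series" means these few. Any claim that something is new, unique, unknown or untested is made for them only; others in the source may bear on it.

Measured so far:
compound 1 `COC(=O)C1=C(C)N=C(C)/C(=C(\O)OC)C1c1ccccc1C#N` — 15.9 nM
compound 2 `COC(=O)C1=C(C)N=C(C)/C(=C(\O)OC)C1c1cccc(N)c1` — 2000 nM
compound 3 `COC(=O)C1=C(C)N=C(C)/C(=C(\O)OC)C1c1ccc(Cl)cc1Cl` — 640 nM

In a functional assay (muscle tissue) with Cavia porcellus as the target (a higher number here means that more compound is needed for the effect, a lower number that less compound is needed), compound 3 gives 640 nM, the second highest of the three numbers: a 3.1-fold lower number from compound 2 to compound 3 (0.49 log units; beyond the scatter) and a 40-fold higher number from compound 1 to compound 3 (1.60 log units; beyond the scatter).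

Compound 4 `COC(=O)C1=C(C)N=C(C)/C(=C(\O)OC)C1c1ccc(F)cc1` differs from compound 3 only at the saturated ring carbon: 4-fluorophenyl in place of 2,4-dichlorophenyl on a saturated ring carbon.

The measured steps at that carbon, a 130-fold higher number from compound 1 to compound 2 (2.10 log units; beyond the scatter) and a 40-fold higher number from compound 1 to compound 3 (1.60 log units; beyond the scatter), were both large, so the aryl group clearly moves this assay. Among the compounds with values here, no measured compound carries a 4-fluorophenyl, so the direction of the step is open. A step of modest size is therefore expected, a 1.3-fold lower number from compound 3 to compound 4 (0.11 log units; within the scatter). Compound 4 is estimated at 500 nM in this assay, with a range from 100 nM to 3000 nM.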

Compound 4, half-maximal effective concentration: 129 nM
For compound 4 the middle estimate is 3.9-fold (0.59 log units) above the measured one; low and high end bracket the measured number.
By their numbers in this assay, from the lowest: compound 1; then compound 4; then compound 3; then compound 2.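

In this assay, 4-fluorophenyl falls in the middle of the aryl groups at the saturated ring carbon: a 5.0-fold lower number from compound 3 to compound 4 (0.70 log units; beyond the scatter) and a 16-fold lower number from compound 2 to compound 4 (1.19 log units; beyond the scatter), but still an 8.1-fold higher number from compound 1 to compound 4 (0.91 log units; beyond the scatter). Among the two halogen-bearing aryl groups, the single fluorine therefore gives the lower number, while the 2-cyanophenyl of compound 1 remains lowest of the four. Nothing measured here bears on the origin of these steps.

The substituent and its place on the phenyl ring change together across these compounds, so their contributions cannot be separated. A 4-cyanophenyl or a 2-fluorophenyl at this carbon remains the open comparison.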